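Cis and trans carbamoyl-dimethylcyclobutyl amines on the shared core

The source may hold more compounds than are shown below. What is called first, only, known or untested is meant among the compounds shown, and "the series" means these compounds.

Measured so far:
compound 1 `CC1(C)C[C@H](Nc2cc(NCc3cnccc3C(F)(F)F)ncc2C#N)CC[C@@H]1O` — 500 nM
compound 2 `CC1(C)[C@@H](C(N)=O)C[C@H]1Nc1cc(NCc2cnccc2C(F)(F)F)ncc1C#N` — 160 nM

In an assay on isolated protein for inhibition of protein kinase C delta type (Homo sapiens), read by TR-FRET, with a stated time of 2 h (a lower number here means a stronger inhibitor, a higher number a weaker inhibitor), compound 2 gives the lowest of the two numbers; its nearest neighbour is compound 1, and the step of a 3.1-fold lower number from compound 1 to compound 2 (0.49 log units; beyond the scatter) replaced the whole saturated ring. Compound 3 `CC1(C)[C@H](Nc2cc(NCc3cnccc3C(F)(F)F)ncc2C#N)C[C@H]1C(N)=O` differs from compound 2 as follows: the two compounds have the same atoms and bonds and differ only in configuration as drawn: 1 of 2 stereo elements differ; a stereocentre at a saturated ring carbon is drawn S in compound 2 and R in compound 3. Within the data shown here, no measured step concerns a change of configuration alone, so the one measured step gives no guide here. A change in either direction is possible, and the expected step of a 1.9-fold higher number from compound 2 to compound 3 (0.27 log units; within the scatter) is therefore uncertain. Compound 3 is estimated at 300 nM in this assay, within 80 nM to 1500 nM.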

Compound 3, half-maximal inhibitory concentration: 900 nM
Estimate against measurement, compound 3: 3.0-fold (0.48 log units) below; low and high end bracket the measured number.
By their numbers in this assay, from the lowest: compound 2; then compounds 1 and 3 (each within the scatter of the next).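

In this assay, the configuration at one saturated ring carbon of the 3-carbamoyl-2,2-dimethylcyclobutyl group matters on its own, with a 5.6-fold higher number from compound 2 to compound 3 (0.75 log units; beyond the scatter). This step can be assigned to that stereocentre alone: the fact that compounds 2 and 3 differ only in the configuration as drawn. The advantage of this group over 4-hydroxy-3,3-dimethylcyclohexyl therefore depends on configuration, since the other form gives a 1.8-fold higher number from compound 1 to compound 3 (0.26 log units; within the scatter).

Going by these compounds, the effect of the second stereo element remains open. Also open, on these data alone, is whether a carboxylic acid or an amine in place of the carbamoyl group would show the same dependence on configuration.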